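A few compounds are considered here, and "the series" means these few. Any claim that something is new, unique, unknown or untested is made for them only; others in the source may bear on it.

In a functional assay on SW-620 cells (Homo sapiens) for cytotoxicity, read by MTT assay, with a stated time of 72 h (on this read-out lower numbers stand for stronger inhibition and higher numbers for weaker inhibition), compound 1 `COc1cccc(/C=C2\CCC/C(=C\c3ccc(Br)cc3)C2=O)c1OC` gives 11100 nM. Compound 2 `COc1ccccc1/C=C1\CCC/C(=C\c2cccc(OC)c2OC)C1=O` differs from compound 1 by 2-methoxyphenyl in place of 4-bromophenyl on a double-bonded chain carbon bound to a double-bonded ring carbon, and in this assay compound 2 reaches only a limit of the assay, > 20000 nM, not a number. That limit, (the limit of > 20000 nM in this assay, at which 1 of the 3 values shown sits), means the step of an at least 1.8-fold higher number from compound 1 to compound 2 (0.25 log units; that floor lies within the scatter) can only be given a floor, and the floor itself lies within the usual scatter, so the change may have cost little or a great deal.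

Compound 3 `COc1ccc(/C=C2\CCC/C(=C\c3ccc(Br)cc3)C2=O)cc1OC` has the same atoms as compound 1 joined differently; the difference between the two cores is not broken down here. In this assay, within the data shown here, compound 3 gives 5200 nM, the lowest of the two numbers measured so far, and its gap to compound 1 lies beyond the scatter.

Compound 4 `COc1ccccc1/C=C1\CCC/C(=C\c2ccc(OC)c(OC)c2)C1=O` stands to compound 3 exactly as compound 2 stands to compound 1: the change is 2-methoxyphenyl in place of 4-bromophenyl on a double-bonded chain carbon bound to a double-bonded ring carbon, at the same place in both pairs, so it is the same change. Among the measured compounds shown here, from the one earlier example, an at least 1.8-fold higher number from compound 1 to compound 2 (0.25 log units; that floor lies within the scatter), the step from compound 3 to compound 4 is expected to be of similar direction, a 2.7-fold higher number from compound 3 to compound 4 (0.43 log units; beyond the scatter), a weakening whose size rests on a single floored comparison. Compound 4 is therefore estimated at 14000 nM, with a range from 6000 nM to 30000 nM, and a real chance that it too is reported only as a limit.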

Compound 4, half-maximal inhibitory concentration: 7800 nM
Compound 4: middle estimate off by 1.8-fold (0.25 log units), on the high side; the range from low to high includes it.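

In this assay, putting 2-methoxyphenyl in place of 4-bromophenyl on the core of compound 3 gives a 1.5-fold higher number from compound 3 to compound 4 (0.18 log units; within the scatter), so on this core the effect of the change cannot be told apart from the ordinary differences between repeated measurements. From the compounds shown here alone, compound 2 gives only a limit of the assay, > 20000 nM, not a number, so the true size of the step on the core of compound 1 remains unknown, and this pair can supply only a floor for the comparison. This means that the two pairs show neither that the change carries over from one core to the other with the same effect nor that its effect depends on the core: the same change on two cores in this assay, an at least 1.8-fold higher number (0.25 log units; that floor lies within the scatter) from compound 1 to compound 2 and a 1.5-fold higher number (0.18 log units; within the scatter) from compound 3 to compound 4; the limit leaves it open whether they differ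

The compounds shown leave open how the same change would behave on a core whose other aromatic ring carries an amine or a carboxylic acid rather than bromine or methoxy groups. They also leave open what a comparison would show if both pairs gave real numbers, since a single pair with two measured values cannot establish a rule for the series.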